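The source may report more compounds than this note shows. Statements on the series, on what has been measured and on what is new or still open speak of the compounds shown alone.

Going by the values given here, in a functional assay on HCT-116 cells (Homo sapiens) for antiproliferative activity, read by sulforhodamine B assay, with a stated time of 72 h (on this read-out higher numbers stand for weaker inhibition and lower numbers for stronger inhibition), compound 1 (`Cn1ncc(Cl)c1-c1cc(C(=O)N[C@@H]2CN[C@H](CCN3CCC(O)CC3)C[C@H]2c2ccc(Cl)c(Cl)c2)oc1Cl`) gives 13700 nM and so holds the higher of the two numbers measured so far. Compound 2 (`CC(=O)NCC[C@@H]1C[C@@H](c2ccc(F)c(F)c2)[C@H](NC(=O)c2cc(-c3c(Cl)cnn3C)c(Cl)o2)CN1`) gives 920 nM which is lower by a margin beyond the scatter. Compound 3 (`Cn1ncc(Cl)c1-c1cc(C(=O)N[C@@H]2CN[C@H](CCN3CCCCC3)C[C@H]2c2ccc(Cl)c(Cl)c2)oc1Cl`) has not yet been measured. It differs from compound 1 in one place (hydrogen in place of hydroxy on a saturated ring carbon): hydrogen in place of hydroxy on a saturated ring carbon, which turns 2-(4-hydroxypiperidin-1-yl)ethyl into 2-(piperidin-1-yl)ethyl. Among the compounds with values here, no measured pair shows this change alone, so its size in this assay can only be judged. A moderate fall in the number is expected, beyond the scatter, and the expected step of a 3.9-fold lower number from compound 1 to compound 3 (0.59 log units; beyond the scatter) is a cautious one. For compound 3 the estimated value is 3500 nM with an expected range from 1000 nM to 12000 nM on this read-out.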

Compound 3, half-maximal inhibitory concentration: 1020 nM
Beside the measured number, compound 3's estimate is 3.4-fold (0.54 log units) above it; the range from low to high includes it.
By their numbers in this assay, from the lowest: compounds 2 and 3 (each within the scatter of the next); then compound 1.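

In this assay, hydrogen in place of hydroxy on this saturated ring carbon, three ring bonds from the ring nitrogen, gives a 13-fold lower number from compound 1 to compound 3 (1.13 log units; beyond the scatter). Going by these compounds alone, this is the first view of this position taken alone, and it shows that the single hydroxy of the 4-hydroxypiperidin-1-yl group has a large bearing on the number, with the rest of compound 1 unchanged. Nothing given here accounts for the size of this step.

The compounds shown leave open whether a methoxy group, an amine or a carboxylic acid on the same ring carbon would read closer to the hydroxy or to the hydrogen. Also open, going by these compounds, is whether the same step would appear with a longer chain in place of the ethyl link to the piperidine.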